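The source may hold more compounds than are shown below. What is called first, only, known or untested is meant among the compounds shown, and "the series" means these compounds.

Measured so far:
compound 1 `c1ccc(-c2ccncc2)c(OCC2=NCCN2)c1` — in a functional assay for activation of Alpha-1B adrenergic receptor (Homo sapiens), read by calcium flux (on this read-out higher numbers stand for an effect only at larger amounts of compound and lower numbers for an effect already at smaller amounts), compound 1 reports only a limit, < 100000 nM.
compound 2 `c1ccc(-c2cc[nH]n2)c(OCC2=NCCN2)c1` — in this assay compound 2 gives 79.4 nM.

For the measured compounds named here, compound 2 holds the only number in this assay; the other value shown is a limit. The step that the limit leaves unreadable from compound 1 to compound 2 stays unreadable because of the limit of < 100000 nM in this assay, at which 1 of the 2 values shown sits. Compound 3 `c1ccc(-c2ccns2)c(OCC2=NCCN2)c1` differs from compound 2 by 1,2-thiazol-5-yl in place of 1H-pyrazol-3-yl on an aromatic carbon. Going by the values given here, no measured step bears readably on this change, since the one step known has no readable size. The change removes the hydrogen-bond donor of the 1H-pyrazol-3-yl group. Compound 1, which also lacks such a donor, sat at a limit, < 100000 nM. The expected step is a loss, a 7.6-fold higher number from compound 2 to compound 3 (0.88 log units; beyond the scatter), with a limit at the weak end not excluded. Compound 3 is estimated at 600 nM, within 80 nM to 6000 nM.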

Compound 3, half-maximal effective concentration: 12.6 nM
For compound 3 the middle estimate is 48-fold (1.68 log units) above the measured one; the measured number lies below the stated range.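

In this assay, the hydrogen-bond donor of the 1H-pyrazol-3-yl group proves dispensable at this place on the six-membered aromatic ring: the 1,2-thiazol-5-yl group, with 0 hydrogen-bond donors, gives a 6.3-fold lower number from compound 2 to compound 3 (0.80 log units; beyond the scatter). Lacking a donor therefore does not go with a weak result across the compounds shown, and a five-membered aromatic ring holding sulfur is accepted here. The steps from compound 1 to compound 2 and from compound 1 to compound 3 cannot be read: the limit of < 100000 nM in this assay, at which 1 of the 3 values shown sits.

The compounds shown do not separate the sulfur of compound 3 from the missing donor as the origin of the step. As far as these compounds go, how a non-aromatic group at this place, such as an amine or a carboxylic acid, would read in this assay also stays open.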